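Nitro to amino on compound 2

A few compounds are considered here, and "the series" means these few. Any claim that something is new, unique, unknown or untested is made for them only; others in the source may bear on it.

Measured in a functional assay on MGC-803 cells (Homo sapiens) for inhibition, read by MTT assay, with a stated time of 48 h; a lower number here means a stronger inhibitor, a higher number a weaker inhibitor:
- compound 1 `C/C=C/C(=O)N(Cc1ccc(OC)c([N+](=O)[O-])c1)c1cc(OC)c(OC)c(OC)c1`: 590 nM
- compound 2 `COc1ccc(CNc2cc(OC)c(OC)c(OC)c2)cc1[N+](=O)[O-]`: 19400 nM
- compound 3 `COc1ccc(CN(C(C)=O)c2cc(OC)c(OC)c(OC)c2)cc1O`: 79 nM

Compound 2 has the highest number of the three. Compound 4 `COc1ccc(CNc2cc(OC)c(OC)c(OC)c2)cc1N` carries amino in place of nitro on an aromatic carbon. Going by the values given here, no measured step changes this place. Among the compounds with values here, the only step, a 33-fold higher number from compound 1 to compound 2 (1.52 log units; beyond the scatter), lies on the nitrogen, so it sets no size here. Compound 3 has no nitro group and also differs on the nitrogen, and its 79 nM hints only loosely at a lower number. A moderate drop in this assay is therefore expected, estimated as a 6.5-fold lower number from compound 2 to compound 4 (0.81 log units; beyond the scatter). For compound 4 the estimated value is 3000 nM, with an expected range of 300 nM to 20000 nM.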

Compound 4, half-maximal inhibitory concentration: 7970 nM
Compound 4: middle estimate off by 2.7-fold (0.42 log units), on the low side; low and high end bracket the measured number.
By their numbers in this assay, from the lowest: compound 3; then compound 1; then compound 4; then compound 2.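

In this assay, going by these compounds alone, the first measured change at this aromatic carbon, amino in place of nitro, gives a 2.4-fold lower number from compound 2 to compound 4 (0.39 log units; beyond the scatter) and so shows that this place affects the number. The step is modest, whereas the earlier change on the nitrogen, a 33-fold higher number from compound 1 to compound 2 (1.52 log units; beyond the scatter), is large. Nothing at hand explains the direction or size of the change at this carbon.

Still open, going by these compounds, is how a dimethylamino group or fluorine at this carbon would compare. Also open, on these data alone, is whether amino in place of nitro gives a similar step when the nitrogen carries the (prop-1-en-1-yl)carbonyl group.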